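This account rests on a few compounds, and the source may have more. Where it says the series, first, only, none or still open, it means among the compounds named here.

Measured so far in a physicochemical assay for acid dissociation:

compound 1, `COc1cccc(CNCCCNc2ccnc3cc(Cc4cccc(C(F)(F)F)c4)ccc23)c1O` — 9.47
compound 2, `COc1cccc(CNCCCNc2ccnc3cc(Cc4ccc(C#N)cc4)ccc23)c1O` — 9.47
compound 3, `N#Cc1ccc(Cc2ccc3c(NCCCNCc4ccco4)ccnc3c2)cc1` — 9.47

The three values sit level with one another within the scatter. From compound 2 to compound 1 the change is 3-(trifluoromethyl)phenyl in place of 4-cyanophenyl on a saturated chain carbon bound to an aromatic carbon, and the step it made was no change at the digits printed from compound 2 to compound 1 (within the scatter). The cores of compound 3 and compound 2 differ by furan-2-yl in place of 2-hydroxy-3-methoxyphenyl on a saturated chain carbon bound to an amine nitrogen, with the step of no change at the digits printed from compound 2 to compound 3 (within the scatter).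

Compound 4, `FC(F)(F)c1cccc(Cc2ccc3c(NCCCNCc4ccco4)ccnc3c2)c1`, is not yet measured. It differs from compound 3 by 3-(trifluoromethyl)phenyl in place of 4-cyanophenyl on a saturated chain carbon bound to an aromatic carbon; the place line matches that of the earlier change word for word, so the change is the same one, occurring twice among these compounds. Because the matching step is no change at the digits printed from compound 2 to compound 1 (within the scatter), the step expected for compound 4 is no change at the digits printed from compound 3 to compound 4 (within the scatter). Compound 4 is therefore estimated at 9.47, with a range from 9.17 to 9.77.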

Compound 4, acid dissociation constant: 9.47
Compound 4: the middle estimate sits on the measured number at the digits printed; the measured number falls inside the stated range.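

In this assay 3-(trifluoromethyl)phenyl in place of 4-cyanophenyl gives no change at the digits printed from compound 3 to compound 4 (within the scatter) on the core carrying furan-2-yl, the same reading as no change at the digits printed from compound 2 to compound 1 (within the scatter) on the core carrying 2-hydroxy-3-methoxyphenyl, and the furan-2-yl change also reads no change at the digits printed from compound 1 to compound 4 (within the scatter) on its second core. So both changes carry across these two cores, but only as steps with nothing to detect, which shows neither that a step of real size would carry nor that other cores would read the same. Nothing available bears on why the four values stand level.

Open, as far as these compounds go, is whether a carboxylic acid on the saturated chain carbon bound to an aromatic carbon would shift the reading. Also open, from the compounds shown here alone, is whether a primary amine on the saturated chain carbon bound to an amine nitrogen would do so.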